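Adding an Amino Group to Two Nucleoside Cores

The compounds below may be only part of what the source reports. "The series", "measured", "known", "first", "only" and "open" are said of these compounds alone.

Compound 1 `COc1ncnc2c1c(-c1cccs1)cn2[C@@H]1O[C@H](CO)[C@@H](O)[C@H]1O` is the strongest inhibitor among the measured compounds: in a functional assay on HCT-116 cells (Homo sapiens), read by MTT assay, with a stated time of 72 h (a higher number here means a weaker inhibitor, a lower number a stronger inhibitor), compound 1 gives 80 nM. Compound 2 `COc1nc(N)nc2c1c(-c1cccs1)cn2[C@@H]1O[C@H](CO)[C@@H](O)[C@H]1O` differs from it by amino in place of hydrogen on an aromatic carbon. Its result is a limit of the assay, not a number: in this assay compound 2 gives > 20000 nM, as noted in the limit of > 20000 nM in this assay, at which 1 of the 3 values shown sits. The step of an at least 250-fold higher number from compound 1 to compound 2 (2.39 log units; beyond the scatter) is therefore large. Compound 3 `O=c1[nH]cnc2c1c(-c1ccco1)cn2[C@@H]1O[C@H](CO)[C@@H](O)[C@H]1O` carries another core; the difference between the two cores is not broken down here. In this assay compound 3 gives 18300 nM. Compound 4 `Nc1nc2c(c(-c3ccco3)cn2[C@@H]2O[C@H](CO)[C@@H](O)[C@H]2O)c(=O)[nH]1`, not yet measured, differs from compound 3 by amino in place of hydrogen on an aromatic carbon. This is the same kind of change as in compound 2, though there the amino group sits meta to a methoxy group (2 heavy atoms), here meta to a group of 1 heavy atom. Guided by an at least 250-fold higher number from compound 1 to compound 2 (2.39 log units; beyond the scatter), the expected step is a 2.7-fold higher number from compound 3 to compound 4 (0.44 log units; beyond the scatter). Compound 4 is thus expected to give about 50000 nM, likely reported only as a limit.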

Compound 4, half-maximal inhibitory concentration: > 20000 nM
Compound 4: a limit, no number; the forecaster's own chance of this, stated with the estimate: 75%; the middle value does not contradict the limit.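

On the second core the result for compound 4 is a limit of the assay, not a number, so only a floor can be given for the step: an at least 1.0-fold higher number from compound 3 to compound 4 (0.03 log units; that floor lies within the scatter). Set beside the first core, this does not show that the change carries over with the same size, nor that its size differs: the same change on two cores in this assay, an at least 250-fold higher number (2.39 log units; beyond the scatter) from compound 1 to compound 2 and an at least 1.0-fold higher number (0.03 log units; that floor lies within the scatter) from compound 3 to compound 4; the limit leaves it open whether they differ. Both amino compounds end at one limit, and compound 3 already lies close to it, so little room remains to read the step on this core: the limit of > 20000 nM in this assay, at which 2 of the 4 values shown sit.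

On these data alone, whether a methyl or a chlorine in place of the amino group, on the same aromatic carbon, would give a real number on both cores stays open. As far as these compounds go, the true size of both steps stays open too.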